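The source may hold more compounds than are shown below. What is called first, only, known or untested is meant among the compounds shown, and "the series" means these compounds.

Working notes on the series. Compound 2 `CC(=O)Nc1cccc(C#Cc2csc(C)n2)c1` gives 2020 nM in a functional assay on CHO cells for agonist activity at metabotropic glutamate receptor 5 (Homo sapiens), read by inositol phosphate accumulation; a lower number here means a stronger inhibitor, a higher number a weaker inhibitor. Among the measured compounds shown here, of the two compounds measured so far it carries the highest number; its nearest neighbour is compound 1 `Cc1nc(C#Cc2cccc(Cl)c2)cs1`, which in this assay gives 129 nM. For the measured compounds named here, the single recorded step, a 16-fold higher number from compound 1 to compound 2 (1.19 log units; beyond the scatter), is the one that separates them, and it is large.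

Compound 3 `Cc1nc(C#Cc2cccc(C(N)=O)c2)cs1` has not yet been measured in this assay. It differs from compound 2 in one place: carbamoyl in place of acetamido on an aromatic carbon, on an aromatic carbon of a six-membered aromatic ring of carbon only, meta to a group of 8 heavy atoms. Going by the values given here, no measured step exchanges these two groups for one another. The step of a 16-fold higher number from compound 1 to compound 2 (1.19 log units; beyond the scatter) bears on it only indirectly: it shows that acetamido in place of chloro raises the number strongly, and carbamoyl, like acetamido, counts one hydrogen-bond donor and one hydrogen-bond acceptor. The expected step is therefore a 1.1-fold higher number from compound 2 to compound 3 (0.04 log units; within the scatter), nothing beyond the scatter in either direction. Compound 3 is estimated at 2200 nM, with a range from 550 nM to 9000 nM.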

Compound 3, half-maximal inhibitory concentration: 1000 nM
Estimate against measurement, compound 3: 2.2-fold (0.34 log units) above; the range from low to high includes it.
By their numbers in this assay, from the lowest: compound 1; then compound 3; then compound 2.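

In this assay this position on the aromatic carbon distinguishes two groups that both count one hydrogen-bond donor and one hydrogen-bond acceptor: carbamoyl in place of acetamido gives a 2.0-fold lower number from compound 2 to compound 3 (0.31 log units; beyond the scatter) and so is a real, if modest, change. Carbamoyl still does not recover the level of chloro (a 7.8-fold higher number from compound 1 to compound 3 (0.89 log units; beyond the scatter)), so most of the rise in a 16-fold higher number from compound 1 to compound 2 (1.19 log units; beyond the scatter) remains with the smaller group, and compound 1 keeps the lowest number of the three. Nothing available gives a reason for either step.

As far as these compounds go, whether a simple amine or a methoxy group, neither carrying a carbonyl, would stand nearer to chloro or to carbamoyl stays open, as does the place of a carboxylic acid or of a longer chain on the amide nitrogen. These three compounds vary only this one position on the shared core, so they cannot tell whether the same order of chloro, carbamoyl and acetamido holds elsewhere on the six-membered ring.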